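Hepatocyte clearance across the hydroxamate series

The source may hold more compounds than are shown below. What is called first, only, known or untested is meant among the compounds shown, and "the series" means these compounds.

Measured so far:
compound 1 `O=C(CCCCCNc1c(Nc2ccccc2)c(=O)c1=O)NO` — < 4.8 uL/min
compound 2 `COc1ccc(Nc2c(NCCCCCC(=O)NO)c(=O)c2=O)cc1` — < 4.7 uL/min

In an ADME assay on cells (Hepatocyte, Homo sapiens) for pharmacokinetics, read by LC-MS, with a stated time of 90 min, tested at 1 uM (a higher number here means faster removal of the compound, a lower number slower removal), compound 1 gives < 4.8 uL/min, which is a limit of the assay and not a number. In this assay compound 2 gives < 4.7 uL/min, again a limit. The step from compound 1 to compound 2, methoxy in place of hydrogen on an aromatic carbon, is a step that the two limits leave unreadable from compound 1 to compound 2; both values sit at limits, the limit of < 4.7 uL/min in this assay, at which 1 of the 2 values shown sits, and (the limit of < 4.8 uL/min in this assay, at which 1 of the 2 values shown sits), so its size cannot be read. Compound 2 thus stands at a limit in this assay, as does compound 1.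

Compound 3 `O=C(CCCCCNc1c(Nc2ccc(C(F)(F)F)cc2)c(=O)c1=O)NO` differs from compound 2 by trifluoromethyl in place of methoxy on an aromatic carbon. Within the data shown here, only the step from compound 1 to compound 2 bears on this change, and its size is unreadable, so no measured step gives a direction. The expected outcome for compound 3 is no step beyond the scatter in this assay, a step that the limit leaves unreadable from compound 2 to compound 3. The estimate for compound 3 is 4 uL/min, between 2 uL/min and 12 uL/min, and a further limit is expected to be the likely report.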

Compound 3, intrinsic clearance in a liver preparation (reported as CLH), per the amount of preparation that the assay uses: 11 uL/min
Compound 3: middle estimate off by 2.8-fold (0.44 log units), on the low side, and the stated range covers the measured number.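

In this assay, among these compounds, the aromatic carbon para to a large group is the first place where a change gives a readable step: trifluoromethyl in place of methoxy gives an at least 2.3-fold higher number from compound 2 to compound 3 (0.36 log units; beyond the scatter) and trifluoromethyl in place of hydrogen gives an at least 2.2-fold higher number from compound 1 to compound 3 (0.36 log units; beyond the scatter). For compound 2 the starting value of its step is a limit and not a number: the limit of < 4.7 uL/min in this assay, at which 1 of the 3 values shown sits. For compound 1 the starting value is also a limit and not a number: the limit of < 4.8 uL/min in this assay, at which 1 of the 3 values shown sits.

Going by these compounds, the true size of both steps stays open, and the step between the two limits cannot be read. Also open, on these data alone, is whether a chlorine, a nitrile or a carboxylic acid at this position, or a longer chain on the shared core, would move the read-out as trifluoromethyl does.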